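A Second Fluoro on the Azepanyl-Bearing Ring

This account rests on a few compounds, and the source may have more. Where it says the series, first, only, none or still open, it means among the compounds named here.

compound 1: `O=C(NCc1ccc(N2CCCCCC2)c(C(F)(F)F)c1)Nc1cccc2[nH]ncc12` — 29.5 nM
compound 2: `O=C(NCc1ccc(N2CCCCCC2)c(F)c1)Nc1cccc2[nH]ncc12` — 14.2 nM

For the measured compounds named here, in a functional assay for antagonist activity at transient receptor potential cation channel subfamily V member 1 (Homo sapiens), read by calcium flux (on this read-out higher numbers stand for weaker inhibition and lower numbers for stronger inhibition), compound 2 gives 14.2 nM, the lowest of the two numbers so far. Going by the values given here, its only neighbour, compound 1, gives 29.5 nM. Among the compounds with values here, the single measured step, a 2.1-fold lower number from compound 1 to compound 2 (0.32 log units; beyond the scatter), followed fluoro in place of trifluoromethyl on an aromatic carbon.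

Compound 3 `O=C(NCc1cc(F)c(N2CCCCCC2)c(F)c1)Nc1cccc2[nH]ncc12` differs from compound 2 by fluoro in place of hydrogen on an aromatic carbon. Within the data shown here, no measured pair shows a hydrogen giving way to fluoro, so the trifluoromethyl-to-fluoro step bears on this change only loosely; it shows that a change at this ring moved the number, but modestly. A step within the scatter, or a small one in either direction, is therefore expected. Compound 3 is expected to give about 12 nM, with a range from 5 nM to 35 nM. That estimate means a step of a 1.2-fold lower number from compound 2 to compound 3 (0.07 log units; within the scatter), expected to stay close to the scatter.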

Compound 3, half-maximal inhibitory concentration: 39.3 nM
Compound 3: middle estimate off by 3.3-fold (0.52 log units), on the low side; measured number above the stated range.
By their numbers in this assay, from the lowest: compound 2; then compounds 1 and 3 (each within the scatter of the next).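

In this assay, for the compounds shown here, this is the first measured case of hydrogen giving way to fluoro on the aromatic carbon ortho to the azepan-1-yl group, and it brings a 2.8-fold higher number from compound 2 to compound 3 (0.44 log units; beyond the scatter) on a ring where the earlier change had gone the other way, with a 2.1-fold lower number from compound 1 to compound 2 (0.32 log units; beyond the scatter) as that earlier step. A fluoro group added at this carbon, meta to the fluoro group already present, therefore costs inhibition, and compound 2, with the single fluoro, keeps the lowest number of the three. Nothing available accounts for this rise.

The compounds shown leave open whether the rise belongs to fluoro itself or to any group at this carbon, as a chloro, methyl or methoxy group there would tell. They also leave open whether the same step would appear with a piperidine or a morpholine in place of the azepan-1-yl group.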